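This account rests on a few compounds, and the source may have more. Where it says the series, first, only, none or still open, it means among the compounds named here.

Measured compounds:
Compound 1, `OC(CCn1nc2c(Br)c(Br)c(Br)c(Br)c2n1)c1cccc(Br)c1`: 0%
Compound 2, `COc1cccc(C(O)CCn2nc3c(Br)c(Br)c(Br)c(Br)c3n2)c1`: 2%

Both compounds share a heavily brominated core and differ only in one group on the pendant phenyl ring. In a functional assay on CCRF-CEM cells (Homo sapiens) for antiproliferative activity, read by MTT assay, with a stated time of 48 h, tested at 50 uM (on this read-out lower numbers stand for a stronger effect and higher numbers for a weaker effect at the one concentration tested), compound 1 gives 0%, and in the same assay compound 2 gives 2%. Compound 2 therefore stands beside compound 1 with no separation that counts: the step of a number 2 percentage points higher from compound 1 to compound 2 (within the scatter) lies within the scatter, so neither compound shows a measurable effect at the concentration tested.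

Compound 3, `OC(CCn1nc2c(Br)c(Br)c(Br)c(Br)c2n1)c1cccc(Cl)c1`, is not yet measured. It differs from compound 2 in one place: chloro in place of methoxy on an aromatic carbon. Within the data shown here, the one measured step that bears on this change is the exchange at the same position between compound 1 and compound 2, a number 2 percentage points higher from compound 1 to compound 2 (within the scatter), which changed nothing beyond the scatter. With a bromo and a methoxy both leaving the read-out at the floor, a chloro at that position is expected to do the same, giving a step of about a number 1 percentage points lower from compound 2 to compound 3 (within the scatter), which is no change beyond the scatter. Compound 3 is therefore estimated at 1%, within a range of 0% to 10%.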

Compound 3, a percentage reported as activity, at one concentration (the size of the read-out at that concentration, not a potency): 0%
For compound 3 the middle estimate is 1 percentage points above the measured one; the range from low to high includes it.
By their numbers in this assay, from the lowest: compounds 1, 3 and 2 (each within the scatter of the next).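

In this assay the position on the phenyl ring now carries a third group, and exchanging methoxy for chloro gives a number 2 percentage points lower from compound 2 to compound 3 (within the scatter) while exchanging bromo for chloro gives no change at the digits printed from compound 1 to compound 3 (within the scatter) in the same test. The methoxy brings two heavy atoms and one hydrogen-bond acceptor and the chloro one heavy atom and no acceptor, yet this difference leaves the read-out within the scatter, so the three groups at this aromatic carbon cannot be told apart at the one concentration tested. Nothing among the data explains why these exchanges leave the number where it is.

Open, on these data alone, is whether an amine or a carboxylic acid on this same aromatic carbon, or a longer chain in place of the present one joining the phenyl ring to the shared core, would move the number beyond the scatter. Also open, as far as these compounds go, is whether the three compounds would separate at a lower concentration, which a reading at a single concentration cannot show.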